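The compounds below may be only part of what the source reports. "The series", "measured", "known", "first", "only" and "open" are said of these compounds alone.

Working notes on the series. Compound 1 `COC(=O)CCNC(=O)[C@H]1CC=C(CCC=C(C)C)C[C@@H]1c1ccccc1` carries a 2-(methoxycarbonyl)ethyl group on the amide nitrogen; in an assay on isolated protein for inhibition of Apoptosis regulator Bcl-2 (Homo sapiens), read by fluorescence polarization, with stated times of 5 min and 10 min (a lower number here means a stronger inhibitor, a higher number a weaker inhibitor), compound 1 gives 3100 nM. Compound 2 `CC(C)=CCCC1=CC[C@H](C(N)=O)[C@@H](c2ccccc2)C1` is the primary amide, with hydrogen in place of that chain. For compound 2 in this assay only a limit of the assay is recorded, > 23000 nM, not a number. The step is therefore bounded on one side only: an at least 7.4-fold higher number from compound 1 to compound 2 (0.87 log units; beyond the scatter); its exact size cannot be stated because one of the two values sits at the assay limit (the limit of > 23000 nM in this assay, at which 1 of the 2 values shown sits). Compound 2 thus stands at the weak end of what has been measured.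

Compound 3 `CC(C)=CCCC1=CC[C@H](C(=O)Nc2ccc(C(=O)O)cc2)[C@@H](c2ccccc2)C1` differs from compound 2 by 4-carboxyphenyl in place of hydrogen on an amide-type nitrogen. Among the compounds with values here, the only measured step that bears on this change is the removal of a substituent from the same amide nitrogen, from compound 1 to compound 2, which weakened inhibition beyond the scatter. Restoring a substituent at that nitrogen is expected to reverse the direction of that step, so for compound 3 a step of an at least 6.5-fold lower number from compound 2 to compound 3 (0.81 log units; beyond the scatter) in this assay is expected. The 4-carboxyphenyl group is not the chain of compound 1, so the size is uncertain. Compound 3 is expected to give about 3500 nM, between 800 nM and 16000 nM.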

Compound 3, inhibition constant: > 23000 nM
Compound 3: no number, only a limit (the forecaster's own chance of this, stated with the estimate: 20%); middle value at least 6.5-fold (0.81 log units) from the limit.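

In this assay compound 3 gives only a limit of the assay, > 23000 nM, not a number. Putting 4-carboxyphenyl on the amide-type nitrogen therefore does not restore the binding seen with the 2-(methoxycarbonyl)ethyl group: replacing that chain gives an at least 7.4-fold higher number from compound 1 to compound 3 (0.87 log units; beyond the scatter), so a substituent at this nitrogen is not enough in itself, and which group stands there matters. The step between compound 2 and compound 3 cannot be read, since both values are limits: the limit of > 23000 nM in this assay, at which 2 of the 3 values shown sit.

Going by these compounds, it remains open whether the activity of compound 1 depends on the ester, on the flexible chain or on both, which a 2-carboxyethyl group or a plain propyl chain on the same nitrogen would help to separate. On these data alone, it is also open whether the aromatic ring or its carboxylic acid accounts for the result with compound 3, a question that a plain phenyl or a 4-(methoxycarbonyl)phenyl group would address.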